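The source may hold more compounds than are shown below. What is called first, only, known or untested is meant among the compounds shown, and "the series" means these compounds.

Measured so far:
compound 1 `N#Cc1ccc(/C=N/Nc2nc(N)c3ncn([C@@H]4O[C@H](CO)[C@@H](O)[C@H]4O)c3n2)cc1`: 4.1 nM
compound 2 `Nc1nc(N/N=C/c2ccc(N3CCCC3)cc2)nc2c1ncn2[C@@H]1O[C@H](CO)[C@@H](O)[C@H]1O`: 5.1 nM
compound 3 `Nc1nc(N/N=C/c2cccnc2Cl)nc2c1ncn2[C@@H]1O[C@H](CO)[C@@H](O)[C@H]1O`: 4.6 nM

In an assay on CHO-K1 cells for displacement of a labelled ligand from adenosine receptor A1 (Homo sapiens), read by scintillation counting, with a stated time of 60 min (on this read-out higher numbers stand for weaker inhibition and lower numbers for stronger inhibition), compound 3 gives 4.6 nM. Its number sits between those of compound 1 and compound 2, and both steps to it are within the scatter: a 1.1-fold higher number from compound 1 to compound 3 (0.05 log units; within the scatter) and a 1.1-fold lower number from compound 2 to compound 3 (0.04 log units; within the scatter). The third measured step, a 1.2-fold higher number from compound 1 to compound 2 (0.09 log units; within the scatter), is likewise within the scatter; every change tried so far swaps one aromatic group for another on the carbon with a double bond to nitrogen.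

Compound 4 `Nc1nc(N/N=C/C2CCCC2)nc2c1ncn2[C@@H]1O[C@H](CO)[C@@H](O)[C@H]1O` differs from compound 3 by cyclopentyl in place of 2-chloropyridin-3-yl on a carbon with a double bond to nitrogen. Among the measured compounds shown here, no measured step exchanges an aromatic ring for a non-aromatic one here, so none bears directly; the flat profile across compounds 1 to 3 only suggests this position tolerates change. Some weakening is expected but uncertain: compound 4 is estimated at 15 nM (range 4 nM to 60 nM), a step of a 3.3-fold higher number from compound 3 to compound 4 (0.51 log units; beyond the scatter) expected.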

Compound 4, inhibition constant: 5.6 nM
Compound 4: the middle estimate sits 2.7-fold (0.43 log units) above what was measured; measured number inside the range.
By their numbers in this assay, from the lowest: compounds 1, 3, 2 and 4 (each within the scatter of the next).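

In this assay cyclopentyl on a carbon with a double bond to nitrogen reads level with all three aromatic groups (a 1.2-fold higher number from compound 3 to compound 4 (0.09 log units; within the scatter); a 1.1-fold higher number from compound 2 to compound 4 (0.04 log units; within the scatter); a 1.4-fold higher number from compound 1 to compound 4 (0.14 log units; within the scatter)). An aromatic ring is therefore not needed at this place among these compounds. Losing the hydrogen-bond acceptor of 2-chloropyridin-3-yl also moves nothing beyond the scatter.

All four groups shown are rings, so a primary amine, a carboxylic acid or a longer alkyl chain on this carbon remains an open case. No measurement shown explains why the numbers stay this flat.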